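This account rests on a few compounds, and the source may have more. Where it says the series, first, only, none or still open, it means among the compounds named here.

Measured compounds in a functional assay on EBC-1 cells (Homo sapiens) for antiproliferative activity, with a stated time of 72 h; a lower number here means a stronger inhibitor, a higher number a weaker inhibitor:
- compound 1 `COc1ccc2c(OCc3nnc4sc(-c5ccc[nH]5)nn34)ccnc2c1`: 313 nM
- compound 2 `COc1ccc2c(OCc3nnc4sc(-c5cnn(C)c5)nn34)ccnc2c1`: 88 nM
- compound 3 `COc1ccc2[nH]c(-c3nn4c(COc5ccnc6cc(OC)ccc56)nnc4s3)cc2c1`: 85.6 nM

Compound 3 gives the lowest of the three numbers, but compound 2 sits within the scatter of it (a 1.0-fold lower number from compound 2 to compound 3 (0.01 log units; within the scatter)); only compound 1 stands clearly apart (a 3.7-fold lower number from compound 1 to compound 3 (0.56 log units; beyond the scatter)).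

Compound 4 `COc1ccc2c(OCc3nnc4sc(-c5ccc(F)cc5)nn34)ccnc2c1` differs from compound 3 by 4-fluorophenyl in place of 5-methoxy-1H-indol-2-yl on an aromatic carbon. Among the compounds with values here, no measured step introduces the group that enters here. The two steps that leave the 1H-pyrrol-2-yl of compound 1, a 3.6-fold lower number from compound 1 to compound 2 (0.55 log units; beyond the scatter) and a 3.7-fold lower number from compound 1 to compound 3 (0.56 log units; beyond the scatter), were both modest and both lowered the number, so the series tolerates varied groups at this carbon. Nothing measured resembles the 4-fluorophenyl, so a small rise in number is expected, a 2.1-fold higher number from compound 3 to compound 4 (0.32 log units; beyond the scatter), with wide uncertainty. Compound 4 is estimated at 180 nM, within 60 nM to 600 nM.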

Compound 4, half-maximal inhibitory concentration: 187 nM
Beside the measured number, compound 4's estimate is 1.0-fold (0.02 log units) below it, and the stated range covers the measured number.
By their numbers in this assay, from the lowest: compounds 3 and 2 (each within the scatter of the next); then compounds 4 and 1 (each within the scatter of the next).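

In this assay, 4-fluorophenyl is the only group shown at this carbon without a ring hetero atom, and it gives modest rises from both groups at the low end of the series: a 2.2-fold higher number from compound 3 to compound 4 (0.34 log units; beyond the scatter) and a 2.1-fold higher number from compound 2 to compound 4 (0.33 log units; beyond the scatter). Against 1H-pyrrol-2-yl there is no separation, a 1.7-fold lower number from compound 1 to compound 4 (0.22 log units; within the scatter), so a ring of carbon only is tolerated here but matches neither of those two groups. Nothing available accounts for these steps.

Still open, from the compounds shown here alone, is how an amine or a carboxylic acid on the phenyl ring, or a saturated morpholine ring at this carbon, would compare.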